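This account rests on a few compounds, and the source may have more. Where it says the series, first, only, none or still open, it means among the compounds named here.

Of the compounds shown here, three sharing one core have been measured in a functional assay on A549 cells (Homo sapiens) for antiproliferative activity, read by MTT assay, with a stated time of 48 h; on this read-out lower numbers stand for stronger inhibition and higher numbers for weaker inhibition. Compound 1 `Cc1ccc(NC(=O)Nc2cccc(NC(=O)c3ccccn3)c2)cc1` gives 20 nM, compound 2 `O=C(Nc1cccc(NC(=S)Nc2ccc([N+](=O)[O-])cc2)c1)c1ccccn1` gives 450 nM, and compound 3 `CN1CCN(C(=S)SCC(=O)Nc2cccc(NC(=O)c3ccccn3)c2)CC1` gives 1340 nM. Compound 3 thus stands with the highest number of the three, further from compound 1 than from compound 2, and both of those gaps lie beyond the usual scatter of the assay.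

Compound 4 `CC(C)(C)OC(=O)N1CCN(C(=S)SCC(=O)Nc2cccc(NC(=O)c3ccccn3)c2)CC1` has not yet been measured. It differs from compound 3 in one place: tert-butoxycarbonyl in place of methyl on an amine nitrogen in a ring. Among the compounds with values here, no measured pair in this set shows a change of this kind, so there is no directly comparable step to lean on.

With nothing in the measured compounds to point either way, the step from compound 3 to compound 4 is expected to be small, a 1.2-fold higher number from compound 3 to compound 4 (0.08 log units; within the scatter), and likely within the scatter. Compound 4 is therefore estimated at 1600 nM, with a plausible range from 500 nM to 5000 nM.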

Compound 4, half-maximal inhibitory concentration: 180 nM
Compound 4: the middle estimate sits 8.9-fold (0.95 log units) above what was measured; measured number outside the range, below it.
By their numbers in this assay, from the lowest: compound 1; then compound 4; then compound 2; then compound 3.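

Tert-butoxycarbonyl in place of methyl on an amine nitrogen in a ring brings a 7.4-fold lower number from compound 3 to compound 4 (0.87 log units; beyond the scatter) in this assay, so the group on this nitrogen has a clear bearing on the read-out. The position accepts the much larger tert-butoxycarbonyl, which adds hydrogen-bond acceptors, and the number falls rather than rises. Nothing available accounts for this step.

Only methyl and tert-butoxycarbonyl are shown on this nitrogen, so it remains open whether the lower number goes with the carbonyl or with the tert-butyl part of the new group. Where an acetyl group, a benzyl group or a plain hydrogen on this nitrogen would stand also remains open, as does whether the same change would have a similar effect on any other core.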